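The compounds below may be only part of what the source reports. "The series", "measured", "known", "first", "only" and "open" are said of these compounds alone.

Measured so far in a functional assay on UACC-62 cells (Homo sapiens) for cytotoxicity, read by sulforhodamine B assay; a lower number here means a stronger inhibitor of growth, a higher number a weaker inhibitor of growth:
compound 1 `CC1=CC[C@@H]([C@@](C)(O)CCCC(C)(C)NC(=S)N/N=C\c2ccc(C)cc2)CC1`: 11600 nM
compound 2 `CC1=CC[C@@H]([C@@](C)(O)CCCC(C)(C)NC(=S)N/N=C\c2cccc([N+](=O)[O-])c2)CC1`: 7840 nM

Among the compounds with values here, compound 1 stands within the scatter of compound 2, the only other measured compound. Compound 3 `CC1=CC[C@@H]([C@@](C)(O)CCCC(C)(C)NC(=S)N/N=C(/C)c2ccccc2)CC1` has the same atoms as compound 1, joined differently: a group of 9 heavy atoms (8 carbon, 1 nitrogen; one six-membered aromatic ring of carbon only) in place of a group of 9 heavy atoms (8 carbon, 1 nitrogen; one six-membered aromatic ring of carbon only), on an amide-type nitrogen. Within the data shown here, the one measured step that changes this part of the structure, a 1.5-fold lower number from compound 1 to compound 2 (0.17 log units; within the scatter), stays within the scatter. It is a different change, so it offers only weak guidance, and no step beyond the scatter is expected in this assay. The expected result is a 1.2-fold lower number from compound 1 to compound 3 (0.09 log units; within the scatter). For compound 3 the estimate is 9500 nM, with an expected range of 4000 nM to 22000 nM.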

Compound 3, concentration for 50% growth inhibition: 22400 nM
Compound 3: middle estimate off by 2.4-fold (0.37 log units), on the low side, outside the stated range (above it).
By their numbers in this assay, from the lowest: compounds 2, 1 and 3 (each within the scatter of the next, the first and the last beyond it).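

In this assay, placing one group of 9 heavy atoms in place of another of the same make-up, on an amide-type nitrogen, gives a 1.9-fold higher number from compound 1 to compound 3 (0.29 log units; within the scatter). The earlier compounds shown here showed only an exchange on the aromatic ring, whereas this step shows that joining the same atoms differently at this position also stays within the scatter. Nothing available explains this result. The compounds shown leave open whether an amine or a carboxylic acid on the aromatic ring, or a longer chain on the carbon with a double bond to nitrogen, would give a step beyond the scatter.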